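Dropping a methoxy from a series without measurable cytotoxicity

This account rests on a few compounds, and the source may have more. Where it says the series, first, only, none or still open, it means among the compounds named here.

Compound 1 `C=CC1=C(C(=O)NCCC)C(c2ccc(F)cc2)OC1` and compound 2 `C=CC1=C(C(=O)NCc2ccccc2)C(c2ccc(OC)c(OC)c2)OC1` share a core and were both tested in a functional assay on HeLa cells (Homo sapiens) for cytotoxicity, read by MTT assay, with a stated time of 24 h; a lower number here means a stronger inhibitor, a higher number a weaker inhibitor. In this assay compound 1 gives > 100000 nM, which is a limit of the assay rather than a number. In this assay compound 2 gives > 100000 nM, likewise a limit and not a number. For the measured compounds named here, compound 2 therefore stands at the limit, as the evidence of the limit of > 100000 nM in this assay, at which 2 of the 2 values shown sit, shows, and no measured step between compounds differing in one place is available. Compound 3 `C=CC1=C(C(=O)NCc2ccccc2)C(c2ccc(OC)cc2)OC1` is the next compound: relative to compound 2 the change is hydrogen in place of methoxy on an aromatic carbon. Going by the values given here, with no measured step to draw on, the step expected in this assay is a step that the limit leaves unreadable from compound 2 to compound 3, meaning no change beyond the scatter. Compound 3 is accordingly estimated to give in this assay about 150000 nM, within 50000 nM to 500000 nM, most likely reported again only as a limit.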

Compound 3, half-maximal inhibitory concentration: > 100000 nM
Compound 3 gave a limit, no number (the forecaster's own chance of this, stated with the estimate: 85%); the middle value is on the limit's open side.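

For the compounds shown here, compound 2 and compound 3 both stand at a limit of the assay rather than at a number, so no step between them can be read. The compounds shown leave open whether any change on the shared core gives a measurable value in this assay.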